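A Methyl Group on a Compound at the Limit

The source may hold more compounds than are shown below. What is called first, only, known or untested is meant among the compounds shown, and "the series" means these compounds.

Compound 1 (`O=C(CCN1CCCCC1)c1cc2ccc(O)cc2oc1=O`) stands at a limit in a functional assay on SH-SY5Y cells (Homo sapiens) for cytotoxicity, read by MTT assay, with stated times of 1 h and 24 h; on this read-out lower numbers stand for an effect already at smaller amounts and higher numbers for an effect only at larger amounts of compound: compound 1 gives > 100000 nM, which is a limit and not a number. Compound 2 (`COc1ccc2cc(C(=O)CCN3CCCCC3)c(=O)oc2c1`) gives > 100000 nM, also a limit. Compound 3 (`CN(C)CCC(=O)c1cc2cc(Br)c(O)c(Br)c2oc1=O`) gives > 100000 nM, again a limit. Within the data shown here, the only measured step, a step that the two limits leave unreadable from compound 1 to compound 2, therefore offers no size to carry over. What remains is the limit of > 100000 nM in this assay, at which 3 of the 3 values shown sit. Compound 4 (`Cc1cc(O)cc2oc(=O)c(C(=O)CCN3CCCCC3)cc12`) differs from compound 1 by methyl in place of hydrogen on an aromatic carbon. Nothing measured points to a change, and the expected step of a number no higher from compound 1 to compound 4 (the limit leaves the size open) is none beyond the scatter. For compound 4 the estimate is 100000 nM, with an expected range from 50000 nM to 200000 nM.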

Compound 4, half-maximal effective concentration: 83700 nM
Beside the measured number, compound 4's estimate is 1.2-fold (0.08 log units) above it; the measured number falls inside the stated range.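

Among these compounds, with methyl in place of hydrogen on an aromatic carbon, this assay gives a number rather than a limit for the first time, showing that a value can be read with this change at this position. On these data alone, the change amounts to an at least 1.1-fold lower number from compound 1 to compound 4 (0.07 log units; that floor lies within the scatter), and its full size stays open. Compound 4 is the only one shown that stands clear of the limit: the limit of > 100000 nM in this assay, at which 3 of the 4 values shown sit.

The compounds shown leave open whether an ethyl group, an amine or a carboxylic acid on this aromatic carbon would give a number different from that of compound 4.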